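Nitrophenyl enaminone series: acetate with methyl on nitrogen

The compounds below may be only part of what the source reports. "The series", "measured", "known", "first", "only" and "open" are said of these compounds alone.

Compound 1 `CN(O)/C=C\C(=O)c1ccc([N+](=O)[O-])cc1` gives 1500 nM in an assay on RBL-1 cells for inhibition of Polyunsaturated fatty acid 5-lipoxygenase (Rattus norvegicus); on this read-out lower numbers stand for stronger inhibition and higher numbers for weaker inhibition. Compound 2 `CC(=O)ON(C)/C=C\C(=O)c1ccc(OCc2ccccc2)cc1` returns only a limit of the assay, > 25000 nM in this assay. Compound 3 `CC(=O)ON(/C=C\C(=O)c1ccc([N+](=O)[O-])cc1)Cc1ccccc1` likewise returns only a limit, > 25000 nM in this assay. Among the compounds with values here, compound 3 therefore stands at the limit of > 25000 nM in this assay, at which 2 of the 3 values shown sit, without a number of its own, and only one of the three values shown is a number. Compound 4 `CC(=O)ON(C)/C=C\C(=O)c1ccc([N+](=O)[O-])cc1` differs from compound 3 by hydrogen in place of phenyl on a saturated chain carbon bound to an amine nitrogen. Within the data shown here, no measured step covers this change; a step of at most modest size is expected, with a further limit the most likely outcome. The expected step from compound 3 to compound 4 is an at least 1.2-fold lower number from compound 3 to compound 4 (0.09 log units; that floor lies within the scatter). For compound 4 the estimate in this assay is 20000 nM, ranging from 4000 nM to 60000 nM.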

Compound 4, half-maximal inhibitory concentration: > 25000 nM
Compound 4 was reported as a limit (the forecaster's own chance of this, stated with the estimate: 55%); middle value at least 1.2-fold (0.09 log units) away from the limit.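

Acetyl in place of hydrogen on an oxygen gives an at least 16-fold higher number from compound 1 to compound 4 (1.22 log units; beyond the scatter), the first readable step in the series, and a large one: with methyl on nitrogen, this single change takes the shared core to a limit in this assay. Compound 4 shares that limit with the other two acetates: the limit of > 25000 nM in this assay, at which 3 of the 4 values shown sit. The steps to compound 4 from compound 2 and compound 3 cannot be read, so neither benzyl to methyl nor nitro in place of benzyloxy has a measurable effect here.

Still open, as far as these compounds go, is how benzyl or benzyloxy reads with the free hydroxyl kept. From the compounds shown here alone, a propionyl group or a methyl ether on that oxygen also remains untested in these data.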